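The source may report more compounds than this note shows. Statements on the series, on what has been measured and on what is new or still open speak of the compounds shown alone.

Working notes on the series. The shared core is seen in compound 1 `O=C(O)CCc1cccc2c1B(O)OC2`; in a functional assay on SK-OV-3 cells (Homo sapiens) for antiproliferative activity, read by MTT assay, with a stated time of 72 h (on this read-out higher numbers stand for weaker inhibition and lower numbers for stronger inhibition), compound 1 gives > 100000 nM, which is a limit of the assay and not a number. Compound 2 `O=C(CCc1cccc2c1B(O)OC2)NCc1ccccc1` carries benzyl on the amide-type nitrogen. In this assay compound 2 gives > 100000 nM, again a limit rather than a measured number. Compound 3 `O=C(CCc1cccc2c1B(O)OC2)Nc1ccc(F)cc1` carries 4-fluorophenyl on the amide-type nitrogen and in this assay gives 720 nM. Going by the values given here, the step of an at least 130-fold lower number from compound 2 to compound 3 (2.14 log units; beyond the scatter) is the only measured step that bears here; it is bounded by the limit of > 100000 nM in this assay, at which 2 of the 3 values shown sit, so only its minimum size is known. Compound 4 `O=C(CCc1cccc2c1B(O)OC2)Nc1ccc(I)cc1` is not yet measured and differs from compound 2 by 4-iodophenyl in place of benzyl on an amide-type nitrogen. The change is of the same kind as that from compound 2 to compound 3, a halogen-bearing phenyl replacing benzyl on the amide-type nitrogen, so a large fall in this assay is expected, estimated as an at least 200-fold lower number from compound 2 to compound 4 (2.30 log units; beyond the scatter). Compound 4 is expected to give about 500 nM, with a range from 150 nM to 2500 nM.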

Compound 4, half-maximal inhibitory concentration: 51000 nM
The estimate for compound 4 lay 100-fold (2.01 log units) below the measured number; the measured number lies above the stated range.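

On the amide-type nitrogen, a halogen-bearing phenyl in place of benzyl does not by itself secure the low number of compound 3: in this assay, iodo in place of fluoro on an aromatic carbon gives a 71-fold higher number from compound 3 to compound 4 (1.85 log units; beyond the scatter). Going by these compounds alone, the choice of halogen therefore matters as much here as the change away from benzyl, although only this one pair of halogens supports that reading. The step of an at least 1.9-fold lower number from compound 2 to compound 4 (0.29 log units; that floor lies within the scatter) gives only a floor, so no gain over benzyl can be claimed for 4-iodophenyl, and its true size stays unknown because it rests on a limit of the assay: the limit of > 100000 nM in this assay, at which 2 of the 4 values shown sit.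

The compounds shown leave open where chloro or bromo would fall relative to fluoro and iodo. They also leave open how an unsubstituted phenyl or an amine on the phenyl ring would compare with 4-fluorophenyl.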